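A few compounds are considered here, and "the series" means these few. Any claim that something is new, unique, unknown or untested is made for them only; others in the source may bear on it.

Measured compounds:
compound 1, `CCc1cccc(NC(=O)CN2CCN(c3ccc(Cl)cn3)CC2)c1`, "not active" (no number reported) in a functional assay on cells for agonist activity at D(4) dopamine receptor (Homo sapiens), read by TR-FRET and cAMP accumulation, with a stated time of 30 min; on this read-out lower numbers stand for an effect already at smaller amounts and higher numbers for an effect only at larger amounts of compound
compound 2, `CCc1cccc(NC(=O)CN2CCN(c3ccccn3)CC2)c1`, 28.7 nM in this assay

Of the two compounds measured in this assay, only compound 2 carries a number: it gives 28.7 nM. Compound 1 is reported in this assay as "not active" (no number reported), so no number stands beside it, and the two cannot be set against each other beyond noting that one of them acts and the other is recorded as not acting. Compound 2 is therefore the only fixed point for this assay.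

Compound 3, `Cc1cccc(NC(=O)CN2CCN(c3ccccn3)CC2)c1`, has not yet been measured in this assay. It keeps the whole of compound 2 apart from one small change: hydrogen in place of methyl on a saturated chain carbon bound to an aromatic carbon. Among the compounds with values here, no step between measured compounds exists to show what this kind of change does here. With only a single carbon removed from a short side chain, the step from compound 2 is expected to be small in this assay, most likely within the usual scatter, with perhaps a slight drift toward a larger amount needed. On that basis compound 3 is estimated at 40 nM, within a range of 14 nM to 120 nM, which would mean an expected step of a 1.4-fold higher number from compound 2 to compound 3 (0.14 log units; within the scatter).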

Compound 3, half-maximal effective concentration: 3.6 nM
Estimate against measurement, compound 3: 11-fold (1.05 log units) above; measured number outside the range, below it.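

In this assay, going from the 3-ethylphenyl group to the 3-methylphenyl group gives an 8.0-fold lower number from compound 2 to compound 3 (0.90 log units; beyond the scatter), so this position is not a silent one: removing one carbon from the chain is enough to move the number clearly. The earlier compounds shown here could not show this, as compound 1 and compound 2 both carry the 3-ethylphenyl group and so said nothing about whether that part of the molecule matters. Nothing measured here explains why the shorter chain goes with the lower number.

From the compounds shown here alone, two groups at this place give a single step and not a trend, so it remains open whether a propyl chain, a methoxy group or plain hydrogen on the ring would take the number further down or bring it back up. Also open, going by these compounds, is whether the same change would restore a measurable effect on the core of compound 1, which gives "not active" (no number reported) in this assay.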